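The source may report more compounds than this note shows. Statements on the series, on what has been measured and on what is new or still open speak of the compounds shown alone.

Working notes on the series. In an assay on microsomes from liver for inhibition of sterol O-acyltransferase 1 (Rattus norvegicus) (on this read-out lower numbers stand for stronger inhibition and higher numbers for weaker inhibition), compound 1 `CCOC(=O)C(F)C(=O)Nc1c(C(C)C)cccc1C(C)C` gives > 1000 nM, which is a limit of this assay and not a number. Compound 2 `CCOC(=O)C(C)(C)C(=O)Nc1c(C(C)C)cccc1C(C)C`, the dimethyl analogue of the same shared core, likewise gives only a limit in this assay, > 1000 nM. Thus the limit of > 1000 nM in this assay, at which 2 of the 2 values shown sit: nothing measured so far places either compound inside the numerical range of this assay, and compound 1 stands at that limit with no finer position.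

Compound 3 `CCCCCCCCCCCCOC(=O)C(F)C(=O)Nc1c(C(C)C)cccc1C(C)C` is not yet measured. It differs from compound 1 by decyl in place of hydrogen on a saturated chain carbon, two bonds along the chain from an oxygen next to a carbonyl group, lengthening the ester chain from ethyl to dodecyl. No measured step within the series shows what such a lengthening does in this assay, so the expected step rests only on the change itself and on the limits shown. A step from the limit toward stronger inhibition is expected, of uncertain size, given that compound 1 gives > 1000 nM as a limit; the step of an at least 3.3-fold lower number from compound 1 to compound 3 (0.52 log units; beyond the scatter) is an estimate. Compound 3 is expected to give 300 nM, within roughly 50 nM to 3000 nM, with a real chance that this assay again reports only a limit.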

Compound 3, half-maximal inhibitory concentration: 32 nM
Estimate against measurement, compound 3: 9.4-fold (0.97 log units) above, and the stated range ends above it.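

In this assay, lengthening the ester chain from ethyl to dodecyl, with decyl in place of hydrogen on a saturated chain carbon, brings the series inside the numerical range of the assay, a large change of an at least 31-fold lower number from compound 1 to compound 3 (1.49 log units; beyond the scatter). Compound 1 gives > 1000 nM, which is a limit and not a number. The step therefore has a floor and no measured size, and the ethyl ester end of the comparison has no exact position: the limit of > 1000 nM in this assay, at which 2 of the 3 values shown sit.

Nothing shown tells whether the number falls steadily with chain length or only past some length, and an octyl ester or a hexadecyl ester on the same core would speak to that. As far as these compounds go, whether the dodecyl ester has the same effect on the dimethyl analogue, compound 2, also stays open.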